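The source may report more compounds than this note shows. Statements on the series, on what has been measured and on what is new or still open speak of the compounds shown alone.

Compound 1, `COc1ccccc1-c1c(C)nn(-c2nc(-c3ccc(Cl)c(Cl)c3)c(SC(C)C)s2)c1C(=O)O`, is measured in a functional assay on BJAB cells (Homo sapiens) for antiproliferative activity, with a stated time of 4 days (a lower number here means that less compound is needed, a higher number that more compound is needed for the effect), at 14700 nM. Compound 2, `CNc1cc(-c2c(C)nn(-c3nc(-c4ccc(Cl)c(Cl)c4)c(SC(C)C)s3)c2C(=O)O)ccn1`, differs from it only in the aromatic group attached to the shared core, with 2-(methylamino)pyridin-4-yl in place of 2-methoxyphenyl on an aromatic carbon, and in this assay compound 2 gives 18000 nM. The step of a 1.2-fold higher number from compound 1 to compound 2 (0.09 log units; within the scatter) is too small to count as a real change, so compound 2 stands, on the two numbers available, side by side with compound 1 and nowhere apart from it.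

Compound 3, `Cc1nn(-c2nc(-c3ccc(Cl)c(Cl)c3)c(SC(C)C)s2)c(C(=O)O)c1-c1cccnc1`, takes the same position one step further: pyridin-3-yl in place of 2-(methylamino)pyridin-4-yl on an aromatic carbon. Within the data shown here, no measured pair shows this exact exchange. Among the measured compounds shown here, the only step that bears on it is a 1.2-fold higher number from compound 1 to compound 2 (0.09 log units; within the scatter), an exchange of one six-membered aromatic group for another at the same aromatic carbon, and it moved the number hardly at all. The expectation is therefore a similar outcome, a step of a 1.1-fold lower number from compound 2 to compound 3 (0.05 log units; within the scatter) with no clear direction beyond the scatter. The estimate for compound 3 in this assay is 16000 nM, with a range from 6000 nM to 45000 nM.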

Compound 3, half-maximal effective concentration: 12000 nM
Beside the measured number, compound 3's estimate is 1.3-fold (0.12 log units) above it, within the range that was stated.
By their numbers in this assay, from the lowest: compounds 3, 1 and 2 (each within the scatter of the next).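

In this assay, the exchange at this aromatic carbon takes away the hydrogen-bond donor of the leaving group and leaves one hydrogen-bond acceptor in place of two, yet the result is a 1.5-fold lower number from compound 2 to compound 3 (0.18 log units; within the scatter). Measured against 2-methoxyphenyl, pyridin-3-yl gives a 1.2-fold lower number from compound 1 to compound 3 (0.09 log units; within the scatter), so all three groups tried at this carbon, one carbocyclic and two with a ring nitrogen, now lie within the scatter of one another, and neither the methylamino group nor the methoxy group is needed to hold the number where it is. Nothing measured here explains why these exchanges leave the number in place.

From the compounds shown here alone, all three compounds carry a six-membered aromatic ring at this carbon, so it remains open whether a five-membered ring such as thiophene, a saturated ring such as morpholine, or a plain chain such as n-butyl would move the number beyond the scatter. Going by these compounds, the carboxy group on the neighbouring ring atom is also the same throughout, so what a primary amide in its place would do is equally open.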